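A Ring Exchange on the Shared Core of Compound 2

A few compounds are considered here, and "the series" means these few. Any claim that something is new, unique, unknown or untested is made for them only; others in the source may bear on it.

In an ADME assay on microsomes from liver (Mus musculus) for metabolic stability, read by LC-MS, using NADPH, with stated times of 15 min and 60 min, tested at 4.6 uM (on this read-out lower numbers stand for a shorter-lived compound and higher numbers for a longer-lived compound), compound 1 `CC(C)CNC(=O)n1c(=O)oc2ccc(C3CCN(C)CC3)cc21` gives 0.667 h as its half-life, compound 2 `CC(C)N1CCC(c2ccc3c(c2)oc(=O)n3C(=O)NCCCCc2ccccc2)CC1` gives 1 h and compound 3 `CN1CCC(c2ccc3c(c2)oc(=O)n3C(=O)NCCCCc2ccc(F)cc2)CC1` gives 0.5 h on the same read-out. Compound 2 stands apart from neither of the others, since its value lies within the usual scatter of both, and the three cannot be ranked.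

The next compound to be tested is compound 4 `CN1CCN(c2ccc3c(c2)oc(=O)n3C(=O)NCCCCc2ccccc2)C(=O)C1` and it differs from compound 2 at a single place: 4-methyl-2-oxopiperazin-1-yl in place of 1-isopropylpiperidin-4-yl on an aromatic carbon on an aromatic carbon of the shared core. Going by the values given here, no two measured compounds differ in one place only, so the data offer no direct guide to this exchange. The measured values show no gap beyond the scatter, and none beyond the scatter is expected here in this assay either. Taking compound 2 at 1 h as the starting point, the expected step is a 1.3-fold lower number from compound 2 to compound 4 (0.10 log units; within the scatter) and no firm direction is implied. Compound 4 is estimated at 0.8 h with a range of 0.3 h to 2 h as the expected span.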

Compound 4, half-life: < 0.0834 h
Compound 4 ended at the assay's limit (the forecaster's own chance of this, stated with the estimate: 10%); middle value at least 9.5-fold (0.98 log units) away from the limit.
By their numbers in this assay, from the lowest: compounds 3, 1 and 2 (each within the scatter of the next). At a limit, below all of these: compound 4.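

The exchange of 1-isopropylpiperidin-4-yl for 4-methyl-2-oxopiperazin-1-yl, on an aromatic carbon of the shared core, brings an at least 11-fold lower number from compound 2 to compound 4 (1.07 log units; beyond the scatter) in this assay. The value of compound 4 is a limit of the assay and not a number: the limit of < 0.0834 h in this assay, at which 1 of the 4 values shown sits. The earlier compounds shown here, all within the scatter of one another, gave no sign that the group at this place could carry a step of this size on the half-life.

The compounds shown leave open whether the step goes with the carbonyl of the entering ring or with its second ring nitrogen, a question on which a 4-methylpiperazin-1-yl group at the same place would bear. They also leave open how far past its limit compound 4 lies.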